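The source may hold more compounds than are shown below. What is called first, only, known or untested is meant among the compounds shown, and "the series" means these compounds.

Of the compounds shown here, three sharing one core have been tested in a functional assay on UO-31 cells (Homo sapiens) for inhibition, read by sulforhodamine B assay, with a stated time of 48 h, tested at 10 uM; a lower number here means less inhibition, a higher number more inhibition at the concentration tested (going by the name of the read-out). Compound 1 `O=Cc1ccc(-c2cn3ccnc3c(-c3ccc4ncn(C5CCCCC5)c4c3)n2)cc1` gives 82.2%. Compound 2 `Fc1ccc(-c2cn3ccnc3c(-c3ccc4ncn(C5CCCCC5)c4c3)n2)cc1` gives 37.8%. Compound 3 `c1cn2cc(-c3ccsc3)nc(-c3ccc4ncn(C5CCCCC5)c4c3)c2n1` gives 23.1%, the lowest of the three numbers; compound 2 is its nearest neighbour, and both of its neighbours stand beyond the scatter above it, with a number 14.7 percentage points lower from compound 2 to compound 3 (beyond the scatter) the smaller gap. Compound 4 `CC(=O)c1ccc(-c2cn3ccnc3c(-c3ccc4ncn(C5CCCCC5)c4c3)n2)cc1` has not yet been measured in this assay. It differs from compound 3 in one place: 4-acetylphenyl in place of thiophen-3-yl on an aromatic carbon. For the measured compounds named here, two measured steps bear on this change. The most direct is a number 59.1 percentage points lower from compound 1 to compound 3 (beyond the scatter), a large fall that the change from compound 3 to compound 4 essentially reverses, the entering group differing from the group of compound 1 only in being acetyl rather than formyl. The second is a number 14.7 percentage points lower from compound 2 to compound 3 (beyond the scatter), a modest fall for a similar swap of a six-membered carbon ring for the thiophen-3-yl group. Both point upward, so a large rise in this assay is expected, though whether an acetyl group restores the full height of compound 1 is uncertain. Compound 4 is therefore expected to give about 68%, between 42% and 88%, which would be an estimated rise of a number 44.9 percentage points higher from compound 3 to compound 4 (beyond the scatter).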

Compound 4, a percentage reported as inhibition, at one concentration (the size of the read-out at that concentration, not a potency): 23.1%
For compound 4 the middle estimate is 44.9 percentage points above the measured one, and the stated range ends above it.
By their numbers in this assay, from the lowest: compounds 3 and 4 (each within the scatter of the next); then compound 2; then compound 1.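

In this assay, the replacement at this position next to the ring nitrogen gives no change at the digits printed from compound 3 to compound 4 (within the scatter) and so separates 4-acetylphenyl from thiophen-3-yl not at all, which the earlier compounds could not have shown. The smallest edit carries the largest consequence: methyl in place of hydrogen on the carbonyl carbon gives a number 59.1 percentage points lower from compound 1 to compound 4 (beyond the scatter) and acetyl in place of fluoro gives a number 14.7 percentage points lower from compound 2 to compound 4 (beyond the scatter), so among these compounds the high number of compound 1 goes with the formyl group and not with a carbonyl on that phenyl ring as such. Nothing measured here accounts for this sharp difference between formyl and acetyl.

The compounds shown leave open whether the high number is unique to the formyl group or would also appear with a carboxylic acid, a hydroxymethyl group or a nitrile on the same phenyl ring. They also leave open how an ethyl ketone or a primary amide would read at this position, and so whether the fall seen with acetyl extends to other carbonyl groups.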